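From an ester to a primary amide on a naphthalene-like core

The source may hold more compounds than are shown below. What is called first, only, known or untested is meant among the compounds shown, and "the series" means these compounds.

Compound 1, with the structure `COC(=O)c1ccc2cc(C(O)(c3c[nH]cn3)C(C)C)ccc2c1`, is the stronger of the two measured compounds in an assay on microsomes from Testis (strain Sprague-Dawley) for inhibition of steroid 17-alpha-hydroxylase/17,20 lyase (Rattus norvegicus) (on this read-out higher numbers stand for weaker inhibition and lower numbers for stronger inhibition), where compound 1 gives 43 nM. Compound 2 `CNC(=O)c1ccc2cc(C(O)(c3c[nH]cn3)C(C)C)ccc2c1C` gives 200 nM in this assay, a clearly higher number. Compound 3 `CC(C)C(O)(c1ccc2cc(C(N)=O)ccc2c1)c1c[nH]cn1` has not been measured. It differs from compound 1 by one change, (amino in place of methoxy on a carbonyl carbon). Among the compounds with values here, no measured pair shows this exact exchange, so its effect is uncertain; a small weakening within or just beyond the scatter is expected, a step of a 1.9-fold higher number from compound 1 to compound 3 (0.27 log units; within the scatter). Compound 3 is therefore estimated at 80 nM in this assay, within a range of 25 nM to 250 nM.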

Compound 3, half-maximal inhibitory concentration: < 10 nM
Compound 3: no number, only a limit; the forecaster's own chance of this, stated with the estimate: 3%; middle value at least 8.0-fold (0.90 log units) from the limit.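

On the carbonyl carbon, the small exchange of methoxy for amino strengthens inhibition in this assay and gives an at least 4.3-fold lower number from compound 1 to compound 3 (0.63 log units; beyond the scatter). This shows that the group at this place can move the read-out beyond the usual scatter. From the compounds shown here alone, the result for compound 3 is a limit of the assay and not a number, so the full size of the gain stays unknown: the limit of < 10 nM in this assay, at which 1 of the 3 values shown sits.

The compounds shown leave open whether the amino group's hydrogens matter here. A dimethylamino group or a hydroxyl on the same carbonyl carbon would help to answer this.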